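The source may hold more compounds than are shown below. What is called first, only, known or untested is meant among the compounds shown, and "the series" means these compounds.

Working notes on the series. In a functional assay on KB cells (Homo sapiens) for cytotoxicity (a lower number here means a stronger inhibitor, a higher number a weaker inhibitor), compound 1 (`C/C=C/C(=O)OC1=CC(=O)c2ccccc2C1=O`) gives 64200 nM and compound 2 (`COc1ccc2c(c1)C(=O)C=CC2=O`) gives 33900 nM. Within the data shown here, these two values lie within the scatter of each other, so compound 1 stands level with the only other measured compound.

Compound 3 (`O=C1C=C(Oc2cccs2)C(=O)c2ccccc21`) has yet to be measured in this assay. It keeps the core of compound 1, and the change is thiophen-2-yl in place of (prop-1-en-1-yl)carbonyl on an oxygen on an unsaturated carbon.

Among the measured compounds shown here, the data hold no measured step between compounds that differ in one place, so the effect of this exchange cannot be read directly. For the measured compounds named here, the only guide is the range marked out by compound 1 at 64200 nM and compound 2 at 33900 nM. No step beyond the scatter is therefore expected, and no firm direction is assumed. The expected step is a 1.8-fold lower number from compound 1 to compound 3 (0.26 log units; within the scatter), an estimate that carries wide uncertainty. For compound 3 the estimated value is 35000 nM, with an expected range of 9000 nM to 100000 nM.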

Compound 3, half-maximal inhibitory concentration: 41500 nM
Beside the measured number, compound 3's estimate is 1.2-fold (0.07 log units) below it, and the stated range covers the measured number.
By their numbers in this assay, from the lowest: compounds 2, 3 and 1 (each within the scatter of the next).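

The exchange gives the series its first measured step at this position: in this assay there is a 1.5-fold lower number from compound 1 to compound 3 (0.19 log units; within the scatter), and this lies within the scatter. The oxygen on an unsaturated carbon whose other neighbours are a double-bonded ring carbon can therefore carry either an open (prop-1-en-1-yl)carbonyl group or a thiophen-2-yl ring, with one five-membered aromatic ring in place of no ring, and the two compounds stand level on the core of compound 1. No supporting measurement beyond these cytotoxicity values bears on this result.

The compounds shown leave open whether any other kind of group on this oxygen, such as a carboxylic acid, an aminoethyl chain or a longer alkyl chain, would give a step beyond the scatter. Also open, from the compounds shown here alone, is whether the level result holds for other aromatic rings, such as phenyl or furan-2-yl, since one exchange at one position defines no trend.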